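Chloro to bromo exchange: expectation for compound 3

A few compounds are considered here, and "the series" means these few. Any claim that something is new, unique, unknown or untested is made for them only; others in the source may bear on it.

Going by the values given here, compound 2 `Nc1nc(-c2ccc(Cl)o2)nc2sc(CN3CCCC3)cc12` is one of two compounds measured so far in an assay on CHO-K1 cells for antagonist activity at adenosine receptor A1 (Homo sapiens), read by a beta-galactosidase reporter, with stated times of 15 min and 6 h (on this read-out higher numbers stand for weaker inhibition and lower numbers for stronger inhibition), where compound 2 gives 710 nM. Among the compounds with values here, its only neighbour is compound 1 `Cc1ccc(-c2nc(N)c3cc(CN4CCCC4)sc3n2)o1`, which gives 620 nM in this assay; the two numbers lie within the scatter of each other, so no order between them can be read. Within the data shown here, the single measured step, a 1.1-fold higher number from compound 1 to compound 2 (0.06 log units; within the scatter), is accordingly small.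

Compound 3 `Nc1nc(-c2ccc(Br)o2)nc2sc(CN3CCCC3)cc12` differs from compound 2 by bromo in place of chloro on an aromatic carbon. Among the measured compounds shown here, the step that bears on this change is a 1.1-fold higher number from compound 1 to compound 2 (0.06 log units; within the scatter), which altered the substituent at the same aromatic carbon and stayed within the scatter; no bromo analogue has been measured, so the expectation rests on that one step alone. Compound 3 is therefore expected to show no step beyond the scatter, a 1.0-fold lower number from compound 2 to compound 3 (0.01 log units; within the scatter). The estimate for compound 3 in this assay is 700 nM, with a range from 300 nM to 1600 nM.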

Compound 3, inhibition constant: 710 nM
Estimate against measurement, compound 3: 1.0-fold (0.01 log units) below; the measured number falls inside the stated range.
By their numbers in this assay, from the lowest: compounds 1, 2 and 3 (each within the scatter of the next).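

In this assay, the change from 5-chlorofuran-2-yl to 5-bromofuran-2-yl gives no change at the digits printed from compound 2 to compound 3 (within the scatter), and bromo in place of methyl on the same aromatic carbon gives a 1.1-fold higher number from compound 1 to compound 3 (0.06 log units; within the scatter). Where the earlier compounds offered a single pair, this position now carries three substituents, methyl, chloro and bromo, all within the scatter of each other, so this read-out does not separate them on the shared core. Nothing in the available data speaks to why these three groups read alike.

Open, on these data alone, is whether a group of another kind on this carbon, such as an amine, a carboxylic acid or a longer alkyl chain, would shift the number beyond the scatter. Also open, as far as these compounds go, is whether this flat reading holds when other parts of the shared core change.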